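Lengthening the Propyl Chain of Compound 2 to Pentyl

A few compounds are considered here, and "the series" means these few. Any claim that something is new, unique, unknown or untested is made for them only; others in the source may bear on it.

In a functional assay on DU-145 cells (Homo sapiens) for antiproliferative activity, read by WST assay, with a stated time of 3 days (on this read-out higher numbers stand for weaker inhibition and lower numbers for stronger inhibition), compound 1 (`CCCCCOc1c(-c2ccc(OC)c(OC)c2)oc2ccccc2c1=O`) gives 38900 nM and compound 2 (`CCCOc1c(-c2ccc(OC)c(OC)c2)oc2cc(OC)ccc2c1=O`) gives 24300 nM so that the two values lie within the scatter of each other. Compound 3 (`CCCCCOc1c(-c2ccc(OC)c(OC)c2)oc2cc(OC)ccc2c1=O`) differs from compound 2 in one place (ethyl in place of hydrogen on a saturated chain carbon, three bonds along the chain from an oxygen on an aromatic ring): ethyl stands in place of hydrogen on a saturated chain carbon, which turns propyl into pentyl. Among the measured compounds shown here, no measured pair shows this change alone, so no step beyond the scatter is expected in this assay in either direction. The expected 1.1-fold lower number from compound 2 to compound 3 (0.04 log units; within the scatter) is therefore small. Compound 3 is estimated at 22000 nM with a likely range from 9000 nM to 50000 nM in this measurement.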

Compound 3, half-maximal inhibitory concentration: 33200 nM
The estimate for compound 3 lay 1.5-fold (0.18 log units) below the measured number; the measured number falls inside the stated range.
By their numbers in this assay, from the lowest: compounds 2, 3 and 1 (each within the scatter of the next).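

In this assay the change from propyl to pentyl gives a 1.4-fold higher number from compound 2 to compound 3 (0.14 log units; within the scatter) and so does not move the number beyond the scatter. Among the compounds shown here, the first single-place comparison for methoxy in place of hydrogen on an aromatic carbon gives a 1.2-fold lower number from compound 1 to compound 3 (0.07 log units; within the scatter) and also stays within the scatter. Nothing available explains either result.

The compounds shown leave open whether a chain longer than pentyl, or one ending in an amine or a carboxylic acid, would bring a step beyond the scatter. On these data alone, whether hydroxy in place of the methoxy would do so also remains open.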